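Fused Ring Replaces Methylphenyl on the Shared Ether

This account rests on a few compounds, and the source may have more. Where it says the series, first, only, none or still open, it means among the compounds named here.

Compound 3 `Cc1ccc(OC2CCN(c3ccc(-n4ccnc4)nn3)CC2)cc1` gives the highest number of the three measured compounds in an assay on microsomes from liver for inhibition of acyl-CoA desaturase 1 (Rattus norvegicus) (on this read-out higher numbers stand for weaker inhibition and lower numbers for stronger inhibition), at 527 nM, while compound 2 `Brc1ccccc1OC1CCN(c2ccc(-n3ccnc3)nn2)CC1` gives 5 nM and compound 1 `O=C(NCCC1CC1)c1ccc(N2CCC(Oc3ccccc3C(F)(F)F)CC2)nn1` gives 14 nM. Compound 4 `c1cc2c(c(OC3CCN(c4ccc(-n5ccnc5)nn4)CC3)c1)CCC2` carries 2,3-dihydro-1H-inden-4-yl in place of 4-methylphenyl on an oxygen on a saturated carbon. Among the compounds with values here, the only step that bears on this change is the one from 2-bromophenyl to 4-methylphenyl, which raised the number by a 110-fold higher number from compound 2 to compound 3 (2.02 log units; beyond the scatter). Since compound 4 again places the additional carbons of its group where compound 2 held its bromine rather than where compound 3 holds its methyl, compound 4 is expected to move a large way back toward compound 2, by a 35-fold lower number from compound 3 to compound 4 (1.55 log units; beyond the scatter). Compound 4 is therefore estimated at 15 nM, within 4 nM to 60 nM.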

Compound 4, half-maximal inhibitory concentration: 10 nM
Compound 4: the middle estimate sits 1.5-fold (0.18 log units) above what was measured; the measured number falls inside the stated range.
By their numbers in this assay, from the lowest: compounds 2, 4 and 1 (each within the scatter of the next, the first and the last beyond it); then compound 3.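

In this assay, 2,3-dihydro-1H-inden-4-yl in place of 4-methylphenyl on the oxygen gives a 53-fold lower number from compound 3 to compound 4 (1.72 log units; beyond the scatter) and shows that a group of carbon only can serve here as well as one carrying bromine. The change from 2-bromophenyl to the same group gives a 2.0-fold higher number from compound 2 to compound 4 (0.30 log units; within the scatter) and leaves the two groups indistinguishable in this assay. No supporting data are available to explain these steps. On these data alone, it remains open how an amine or a carboxylic acid on the aromatic ring would fare at this position.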